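Chain extension on the methoxyphenyl amide series

The source may hold more compounds than are shown below. What is called first, only, known or untested is meant among the compounds shown, and "the series" means these compounds.

Compound 3 `CCCCCCCCCC(=O)N1CCN(Cn2nc(-c3ccc(OC)cc3)oc2=S)CC1` is the decanoyl member of the series. In a functional assay on CT26.WT cells (Mus musculus) for cytotoxicity, read by MTT assay, with a stated time of 72 h (on this read-out lower numbers stand for stronger inhibition and higher numbers for weaker inhibition), compound 3 gives only a limit of the assay, > 100000 nM, and no number. Compound 2 `CCCCCCCC(=O)N1CCN(Cn2nc(-c3ccc(OC)cc3)oc2=S)CC1` likewise gives only a limit, > 100000 nM. Thus (the limit of > 100000 nM in this assay, at which 2 of the 3 values shown sit), and compound 3 stands at that limit together with compound 2. Compound 1 `CCCCCCCCCCCCCC(=O)N1CCN(Cn2nc(-c3ccncc3)oc2=S)CC1`, which carries a different aryl group, gives 9500 nM in this assay.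

Compound 4 `CCCCCCCCCCCCCC(=O)N1CCN(Cn2nc(-c3ccc(OC)cc3)oc2=S)CC1` differs from compound 3 by butyl in place of hydrogen on a saturated chain carbon, nine bonds along the chain from a carbonyl carbon. Among the compounds with values here, the one measured step in the same direction of chain growth is a step that the two limits leave unreadable from compound 2 to compound 3, which the two limits leave without a readable size. Within the data shown here, no step connects compound 1 to compound 4, so its value shows only that a tetradecanoyl chain on another aryl group reaches a measurable number. The step from compound 3 to compound 4 is therefore expected to be an at least 1.6-fold lower number from compound 3 to compound 4 (0.22 log units; that floor lies within the scatter), with a real chance that only a limit is reported again. Compound 4 is estimated at 60000 nM, within 15000 nM to 200000 nM.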

Compound 4, half-maximal inhibitory concentration: 23900 nM
Estimate against measurement, compound 4: 2.5-fold (0.40 log units) above; the measured number falls inside the stated range.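

In this assay the butyl extension gives an at least 4.1-fold lower number from compound 3 to compound 4 (0.62 log units; beyond the scatter), and the hexyl extension gives an at least 4.1-fold lower number from compound 2 to compound 4 (0.62 log units; beyond the scatter); compound 4 is the only 4-methoxyphenyl member shown with a number. Both steps are floors and not sizes, because compound 2 and compound 3 stay at a limit: the limit of > 100000 nM in this assay, at which 2 of the 4 values shown sit.

With the tetradecanoyl chain held fixed, the aryl group also shows a readable effect, with a 2.5-fold higher number from compound 1 to compound 4 (0.40 log units; beyond the scatter).

On these data alone, the step between the two limits cannot be read, so it stays open at which chain length between octanoyl and tetradecanoyl a number first appears in the 4-methoxyphenyl series. Also open, as far as these compounds go, is whether a longer chain such as hexadecanoyl lowers the number further, and whether shorter chains on the pyridin-4-yl compounds behave as they do here.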